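Aryl alkyne on the uracil side chain of compound 2

A few compounds are considered here, and "the series" means these few. Any claim that something is new, unique, unknown or untested is made for them only; others in the source may bear on it.

Two measured compounds share a core in which an alkyne substituent sits on the uracil ring. Compound 1 `CCCCCCCCC#Cc1cn(C/C=C\CN2C(=O)c3ccccc3C2=O)c(=O)[nH]c1=O` gives 36000 nM in a functional assay on MOLT-4 cells (Homo sapiens) for antiproliferative activity, read by MTT assay, with a stated time of 3 days (on this read-out higher numbers stand for weaker inhibition and lower numbers for stronger inhibition), and compound 2 `CCCCC#Cc1cn(C/C=C\CN2C(=O)c3ccccc3C2=O)c(=O)[nH]c1=O` gives 41000 nM in this assay. The step of a 1.1-fold higher number from compound 1 to compound 2 (0.06 log units; within the scatter) shows that shortening the chain left the value essentially unchanged. Compound 2 thus stands highest of the two numbers, though its distance from compound 1 is within the scatter.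

Compound 3 `CCCCc1ccc(C#Cc2cn(C/C=C\CN3C(=O)c4ccccc4C3=O)c(=O)[nH]c2=O)cc1` carries the change (4-butylphenyl in place of butyl on a triple-bonded carbon). Among the compounds with values here, only the step from compound 1 to compound 2 bears on it, and that step was within the scatter; no measured pair shows what an aromatic ring on the alkyne does. In this assay compound 3 is therefore expected to give 25000 nM, ranging from 8000 nM to 70000 nM. The expected step of a 1.6-fold lower number from compound 2 to compound 3 (0.21 log units; within the scatter) is estimated to lie at most a little beyond the scatter, toward a lower number.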

Compound 3, half-maximal inhibitory concentration: 31000 nM
Compound 3: middle estimate off by 1.2-fold (0.09 log units), on the low side; measured number inside the range.
By their numbers in this assay, from the lowest: compounds 3, 1 and 2 (each within the scatter of the next).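

In this assay, 4-butylphenyl in place of butyl on a triple-bonded carbon gives a 1.3-fold lower number from compound 2 to compound 3 (0.12 log units; within the scatter), and 4-butylphenyl in place of octyl gives a 1.2-fold lower number from compound 1 to compound 3 (0.06 log units; within the scatter). The earlier pair had covered alkyl chains only; these steps show that a six-membered aromatic ring of carbon only can also stand at this position with no step beyond the scatter, so that all three compounds lie within the scatter of one another. Nothing at hand offers an explanation for how closely these numbers lie.

As far as these compounds go, whether an amine or a carboxylic acid on the aromatic ring would move the number beyond the scatter remains open. So does the effect of an unsubstituted phenyl, which would separate the ring from the butyl chain it carries in compound 3.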